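Benzyl-triazole ethers of one core, pending compound 3

The compounds below may be only part of what the source reports. "The series", "measured", "known", "first", "only" and "open" are said of these compounds alone.

Measured so far:
compound 1 `O=c1ccoc2cc(OCc3cn(Cc4cccc(Br)c4)nn3)ccc12`: > 100000 nM
compound 2 `Cc1ccccc1Cn1cc(COc2ccc3c(=O)ccoc3c2)nn1`: > 100000 nM

In a functional assay on A549 cells (Homo sapiens) for cytotoxicity, read by MTT assay, with a stated time of 48 h (a lower number here means a stronger inhibitor, a higher number a weaker inhibitor), compound 1 gives > 100000 nM, which is a limit of the assay and not a number. In this assay compound 2 gives > 100000 nM, likewise a limit of the assay. The change between them, a step that the two limits leave unreadable from compound 1 to compound 2, is therefore unreadable in size and direction. Compound 2 thus stands at the limit, as does every value shown: the limit of > 100000 nM in this assay, at which 2 of the 2 values shown sit.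

Compound 3 `O=c1ccoc2cc(OCc3cn(Cc4ccc(Cl)cc4Cl)nn3)ccc12` differs from compound 2 in one place, (2,4-dichlorophenyl in place of 2-methylphenyl on a saturated chain carbon bound to an aromatic nitrogen). Within the data shown here, the only measured step, a step that the two limits leave unreadable from compound 1 to compound 2, gives no readable size, so no measured step bears on this change in a way that would predict a shift in this assay. What the two shown values offer is that both aryl variants so far sit at the limit.

On that basis compound 3 is expected to remain at or near the limit in this assay, with an estimated 150000 nM and a range of 40000 nM to 600000 nM; the step this estimate means is a step that the limit leaves unreadable from compound 2 to compound 3, expected to be none beyond the scatter.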

Compound 3, half-maximal inhibitory concentration: 5260 nM
Compound 3: middle estimate off by 29-fold (1.46 log units), on the high side, and the stated range ends above it.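

In this assay, the place on a saturated chain carbon bound to an aromatic nitrogen now proves able to move the read-out: 2,4-dichlorophenyl in place of 2-methylphenyl gives an at least 19-fold lower number from compound 2 to compound 3 (1.27 log units; beyond the scatter), and 2,4-dichlorophenyl in place of 3-bromophenyl gives an at least 19-fold lower number from compound 1 to compound 3 (1.27 log units; beyond the scatter). Both steps start from a limit of the assay, so each sets a minimum size and not an exact one, while the step between compound 1 and compound 2 cannot be read. The earlier pair could not show that the aryl group at this place matters, and compound 3 is the first compound shown to lie off the limit: the limit of > 100000 nM in this assay, at which 2 of the 3 values shown sit.

The compounds shown leave open whether both chlorines of 2,4-dichlorophenyl are needed for this step, which a monochlorophenyl group at the same place would test. Also open, from the compounds shown here alone, is whether a more distant change at this place, such as a pyridyl ring or a longer chain ending in an amine, would keep, lose or extend the step in this assay.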